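Chloro for bromo on the chalcone aryl ring

The source may report more compounds than this note shows. Statements on the series, on what has been measured and on what is new or still open speak of the compounds shown alone.

The shared core of this series is seen in compound 1 `COc1ccc(C(=O)/C=C/c2ccc(Br)cc2)c2c1C=CC(C)(C)O2`, which carries a 4-bromophenyl on the double-bonded chain. In a functional assay on HCT-116 cells (Homo sapiens) for antiproliferative activity, read by MTT assay, with a stated time of 24 h (on this read-out lower numbers stand for stronger inhibition and higher numbers for weaker inhibition), compound 1 gives only a limit of > 10000 nM. Two further compounds share this core with other aryl groups: compound 2 `COc1ccc(C(=O)/C=C/c2ccc(N(c3ccccc3)c3ccccc3)cc2)c2c1C=CC(C)(C)O2` and compound 3 `COc1ccc(C(=O)/C=C/c2cccc3ccccc23)c2c1C=CC(C)(C)O2`. In this assay compound 2 also gives only a limit of > 10000 nM. Compound 3 likewise gives only a limit of > 10000 nM in this assay. So compound 1 stands level with the other two measured compounds, and none of the three has a number within the measurable range; what unites them is the limit of > 10000 nM in this assay, at which 3 of the 3 values shown sit.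

The unmeasured compound 4 `COc1ccc(C(=O)/C=C/c2cccc(Cl)c2)c2c1C=CC(C)(C)O2` differs from compound 1 in one place: 3-chlorophenyl in place of 4-bromophenyl on a double-bonded chain carbon bound to a double-bonded chain carbon. Within the data shown here, the three measured compounds span quite different aryl groups without any of them leaving the limit, and no measured step within this set gives a guide to the size of this change. It is therefore expected that the step in this assay is none beyond the scatter, and that compound 4 remains at or near the limit. The expected step from compound 1 to compound 4 is a step that the limit leaves unreadable from compound 1 to compound 4. Compound 4 is estimated at 15000 nM, in a range from 5000 nM to 50000 nM.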

Compound 4, half-maximal inhibitory concentration: > 10000 nM
Compound 4: only a limit was reported (the forecaster's own chance of this, stated with the estimate: 75%); the middle value lies beyond the limit too.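

Compound 1 and compound 4 are both reported in this assay only as limits, so no step between them can be read, and the comparison ends at a shared limit: the limit of > 10000 nM in this assay, at which 4 of the 4 values shown sit.

The compounds shown leave open which aryl group on the shared core, if any, would give a value within the measurable range.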